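The source may report more compounds than this note shows. Statements on the series, on what has been measured and on what is new or still open speak of the compounds shown alone.

Measured so far in a functional assay on cells for agonist activity at G-protein coupled receptor 52 (Homo sapiens), read by AlphaScreen and cAMP accumulation, with a stated time of 30 min; a lower number here means a smaller maximal response, a higher number a larger maximal response:
compound 1 `Cc1cc(-c2sc(Cc3cccc(C(F)(F)F)c3)nc2C)ccc1C(N)=O` gives 86%
compound 2 `Cc1cc(C(N)=O)ccc1-c1sc(Cc2cccc(C(F)(F)F)c2)nc1C` gives 87%
compound 3 `CCc1cc(-c2sc(Cc3cccc(C(F)(F)F)c3)nc2C)ccc1C(N)=O` gives 84%

Compound 1 stands second highest of the three numbers; its nearest neighbour is compound 2, and the number for compound 3 lies furthest from it, yet both gaps are within the scatter, so the three compounds cannot be ordered on these values.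

The next compound, compound 4 `Cc1nc(Cc2cccc(C(F)(F)F)c2)sc1-c1ccc(C(N)=O)c(C(C)C)c1`, differs from compound 1 in one place: isopropyl in place of methyl on an aromatic carbon. The group enters on an aromatic carbon of the six-membered aromatic ring of carbon only, ortho to the carbamoyl group and meta to the large group.

Among the measured compounds shown here, only one measured step bears on this change, the one that also enlarges the group at this place: a number 2 percentage points lower from compound 1 to compound 3 (within the scatter). That step stayed within the scatter, which gives no sign that enlarging the group here moves the maximal response. As far as these compounds go, whether a branched group behaves the same is untested; the measured set holds no isopropyl anywhere. On this basis, no step beyond the scatter is expected in this assay from compound 1 to compound 4: a number 2 percentage points lower from compound 1 to compound 4 (within the scatter). For compound 4 the expected maximal response is 84%, with a range of 72% to 94%, the range widened for the untested size of the group.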

Compound 4, largest response reached (Emax), in percent of the reference or control that the assay uses: 63%
For compound 4 the middle estimate is 21 percentage points above the measured one; the whole stated range lies above it.
By their numbers in this assay, from the lowest: compound 4; then compounds 3, 1 and 2 (each within the scatter of the next).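

In this assay, the place ortho to a carbamoyl group does respond to the group it carries, which compound 3 alone gave no sign of: the loss appears only with isopropyl (a number 23 percentage points lower from compound 1 to compound 4 (beyond the scatter)). The single added methyl that separates the chain of compound 3 from the isopropyl of compound 4 is enough to produce a step of nearly the same size (a number 21 percentage points lower from compound 3 to compound 4 (beyond the scatter)), whereas the step that added a methyl to the chain of compound 1 stays within the scatter (a number 2 percentage points lower from compound 1 to compound 3 (within the scatter)). The maximal response at this place therefore does not fall evenly with each added carbon across compounds 1, 3 and 4, and no measurement shown here explains the drop.

These compounds cannot separate branching from the plain count of carbons, so a straight propyl chain, a cyclopropyl ring and a tert-butyl group at this place remain the open comparisons. As far as these compounds go, it is also open whether a group other than a plain hydrocarbon, such as methoxy or chloro, would keep the maximal response of compound 1 or fall toward that of compound 4.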